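The compounds below may be only part of what the source reports. "The series", "measured", "known", "first", "only" and "open" are said of these compounds alone.

Working notes on the series. Compound 3 `Cc1cc(-c2c(C)nn(C)c2C)ccc1-c1nnc(N(C)Cc2ccc3ncc(C4CCN(C)CC4)n3c2)o1` holds the lowest number of the three measured in a physicochemical assay for lipophilicity, at pH 7.4; a lower number here means a more polar compound, a higher number a more lipophilic compound: compound 3 gives 2.5, compound 1 `Cc1cc(-c2c(C)nn(C)c2C)ccc1-c1nnc(N(C)Cc2ccc3nccn3c2)o1` gives 3.7 and compound 2 `Cc1cc(-c2c(C)nn(C)c2C)ccc1-c1nnc(N(C)Cc2ccc3ncc(-c4ccccc4)n3c2)o1` gives 5.3. Compound 4 `Cc1cc(-c2c(C)nn(C)c2C)ccc1-c1nnc(N(C)Cc2ccc3ncc(-c4cnn(CCN(C)C)c4)n3c2)o1` carries 1-(2-(dimethylamino)ethyl)-1H-pyrazol-4-yl in place of 1-methylpiperidin-4-yl on an aromatic carbon. Of the measured steps, a number 1.20 log units lower from compound 1 to compound 3 (beyond the scatter) and a number 1.60 log units higher from compound 1 to compound 2 (beyond the scatter) bear on it, both at the same place on the core; they bracket the outcome of adding a carbon-rich aromatic group against a basic saturated ring there. Compound 4 keeps a basic amine and adds an aromatic ring, so a step upward of moderate size, a number 0.30 log units higher from compound 3 to compound 4 (within the scatter), is expected, staying well below compound 2. Compound 4 is estimated at 2.8, within 2 to 3.6 in this assay.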

Compound 4, distribution coefficient: 3.5
For compound 4 the middle estimate is 0.70 log units below the measured one; the measured number falls inside the stated range.
By their numbers in this assay, from the lowest: compound 3; then compounds 4 and 1 (each within the scatter of the next); then compound 2.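

In this assay, the swap at this aromatic carbon is not neutral between the two amine-bearing groups: a number 1.00 log units higher from compound 3 to compound 4 (beyond the scatter). 1-(2-(dimethylamino)ethyl)-1H-pyrazol-4-yl still sits well apart from phenyl, a number 1.80 log units lower from compound 2 to compound 4 (beyond the scatter). Unlike phenyl and 1-methylpiperidin-4-yl, it gives no step beyond the scatter against hydrogen, a number 0.20 log units lower from compound 1 to compound 4 (within the scatter). No evidence at hand accounts for these differences. Still open, from the compounds shown here alone, is whether the pyrazole ring or the dimethylaminoethyl chain sets the step; 1-methyl-1H-pyrazol-4-yl, or a morpholine on the same ethyl chain, would separate the two.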